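Ring-nitrogen substituent: butyl amine to cyclopropyl amide

The compounds below may be only part of what the source reports. "The series", "measured", "known", "first", "only" and "open" are said of these compounds alone.

Compound 2, `CCCCN1CCc2nc(C#Cc3ccccc3)sc2C1`, is the weakest point among the three results so far in an assay on HEK293 cells for negative allosteric modulation of metabotropic glutamate receptor 5 (Homo sapiens), read by FLIPR, with a stated time of 1 h; a lower number here means a stronger inhibitor, a higher number a weaker inhibitor. For compound 2 the assay returns only a limit, > 10000 nM, which is the limit of > 10000 nM in this assay, at which 1 of the 3 values shown sits. Compound 1, `O=C1c2sc(C#Cc3ccccc3)nc2CN1C1CC1`, gives 23 nM in this assay, and compound 3, `Fc1cccc(C#Cc2nc3c(s2)CN(C2CCOC2)CC3)c1`, gives 400 nM in this assay; both therefore lie clearly inside the measurable range, with the gap between compound 1 and compound 3 also larger than the usual scatter.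

The untested compound 4, `O=C(C1CC1)N1CCc2nc(C#Cc3ccccc3)sc2C1`, is reached from compound 2 by cyclopropylcarbonyl in place of butyl on an amine nitrogen in a ring. Among the measured compounds shown here, no measured pair shows this exact change, so the size of the step must be estimated. Compound 4 is expected to move well into the measurable range, a step of an at least 66-fold lower number from compound 2 to compound 4 (1.82 log units; beyond the scatter), a gain far beyond the scatter rather than no change. The expectation rests on compound 1, which also carries a carbonyl on its ring nitrogen and gives 23 nM in this assay. Compound 4 is therefore estimated at 150 nM, within a range of 25 nM to 1500 nM.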

Compound 4, half-maximal inhibitory concentration: 290 nM
Compound 4: middle estimate off by 1.9-fold (0.29 log units), on the low side; measured number inside the range.
By their numbers in this assay, from the lowest: compound 1; then compounds 4 and 3 (each within the scatter of the next). At a limit, above all of these: compound 2.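

Among the compounds shown here, on the amine nitrogen in a ring, cyclopropylcarbonyl in place of butyl gives the first step that can be read in this assay: an at least 34-fold lower number from compound 2 to compound 4 (1.53 log units; beyond the scatter). This single change on the shared core is enough to move a compound from a limit to a measured value, so substitution at this nitrogen has a large bearing on the read-out. Compound 2 remains a limit, so the step has a lower bound and no exact size: the limit of > 10000 nM in this assay, at which 1 of the 4 values shown sits.

The step changes the chain and adds the carbonyl in one move, so it does not tell which of the two carries the gain; a butanoyl or a cyclopropylmethyl on the same nitrogen would separate them. Compound 1 and compound 3 each differ from compound 4 in more than one place, so neither shows how far this result extends.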